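A few compounds are considered here, and "the series" means these few. Any claim that something is new, unique, unknown or untested is made for them only; others in the source may bear on it.

Measured so far:
compound 1 `COc1ccc(/C=C/c2cc(OC)cc(OC)c2/C=C/C(=O)N2CCCC2)cc1` — 4200 nM
compound 2 `COc1ccc(/C=C/c2cc(OC)cc(OC)c2/C=C/C(=O)NC(C)C)cc1` — 2560 nM

In a functional assay on MCF7 cells (Homo sapiens) for inhibition, read by MTT assay, with a stated time of 48 h (on this read-out higher numbers stand for weaker inhibition and lower numbers for stronger inhibition), compound 2 gives the lower of the two numbers, but the step of a 1.6-fold lower number from compound 1 to compound 2 (0.22 log units; within the scatter) lies within the scatter, so the two compounds cannot be told apart on this read-out. Compound 3 `CCCCN(CCCC)C(=O)/C=C/c1c(/C=C/c2ccc(OC)cc2)cc(OC)cc1OC` carries the change (dibutylamino in place of isopropylamino on a carbonyl carbon). Among the compounds with values here, the only measured step that touches the same carbonyl carbon is a 1.6-fold lower number from compound 1 to compound 2 (0.22 log units; within the scatter), an exchange of one amine substituent for another that produced nothing beyond the scatter. Within the data shown here, no measured pair shows what dibutylamino does here. On that basis the expectation for compound 3 is no step beyond the scatter, in either direction. The estimate for compound 3 is 3000 nM, with a range of 1200 nM to 8000 nM. The step this estimate implies, a 1.2-fold higher number from compound 2 to compound 3 (0.07 log units; within the scatter), is expected to remain within the scatter.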

Compound 3, half-maximal inhibitory concentration: 3990 nM
Beside the measured number, compound 3's estimate is 1.3-fold (0.12 log units) below it; the range from low to high includes it.
By their numbers in this assay, from the lowest: compounds 2, 3 and 1 (each within the scatter of the next).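

Across the substituents on this carbonyl carbon, this assay now shows a 1.6-fold higher number from compound 2 to compound 3 (0.19 log units; within the scatter) and also a 1.1-fold lower number from compound 1 to compound 3 (0.02 log units; within the scatter), both within the scatter. The earlier pair compared only isopropylamino with pyrrolidin-1-yl; dibutylamino, which has two butyl chains and lacks the amide hydrogen of compound 2, now extends that comparison, and compound 3 cannot be told apart from either compound 2 or compound 1 on this read-out. No measurement on hand gives a reason for this result.

From the compounds shown here alone, whether any group at this place can move the number beyond the scatter remains open. A carboxylic acid, or a chain ending in a dimethylamino group on the amide nitrogen, would test this with a substituent unlike the three simple alkyl amines shown here.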